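A few compounds are considered here, and "the series" means these few. Any claim that something is new, unique, unknown or untested is made for them only; others in the source may bear on it.

Compound 1 `CC(CCO)n1cnc2c(Cl)nc(F)nc21` and compound 2 `CCC(CCO)n1cnc2c(Cl)nc(F)nc21` share one core and differ in a single place: methyl in place of hydrogen on a saturated chain carbon, two bonds along the chain from an aromatic nitrogen. In a functional assay on HCT-116 cells (Homo sapiens) for antiproliferative activity, read by MTT assay, with a stated time of 48 h (a lower number here means a stronger inhibitor, a higher number a weaker inhibitor), compound 1 gives 19800 nM, and compound 2 gives 18900 nM, so that a 1.0-fold lower number from compound 1 to compound 2 (0.02 log units; within the scatter). Compound 3 `CCCCCCCC[C@H](CCO)n1cnc2c(Cl)ncnc21` carries a different core, and the difference between the two cores is not broken down here. In this assay compound 3 gives 1120 nM, the lowest of the three numbers and beyond the scatter from both compound 1 and compound 2. Compound 4 `CCCCCCCCC[C@H](CCO)n1cnc2c(Cl)ncnc21` has not yet been measured. It differs from compound 3 in one place: methyl in place of hydrogen on a saturated chain carbon, nine bonds along the chain from an aromatic nitrogen. The change from compound 1 to compound 2 sits two bonds along the chain from an aromatic nitrogen, whereas this one sits nine bonds along the chain from an aromatic nitrogen, so it is the same kind of change rather than the same change. The step from compound 3 to compound 4 is expected to be small, a 1.2-fold lower number from compound 3 to compound 4 (0.07 log units; within the scatter), because a 1.0-fold lower number from compound 1 to compound 2 (0.02 log units; within the scatter) gave no movement. Compound 4 is expected to give about 950 nM in this assay, with a span from 350 nM to 2600 nM.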

Compound 4, half-maximal inhibitory concentration: 450 nM
For compound 4 the middle estimate is 2.1-fold (0.32 log units) above the measured one, and the stated range covers the measured number.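

In this assay, methyl in place of hydrogen on a saturated chain carbon, nine bonds along the chain from an aromatic nitrogen, gives a 2.5-fold lower number from compound 3 to compound 4 (0.40 log units; beyond the scatter), a modest step. Set beside the earlier step on the other core, this one does not differ from it by more than the scatter allows: the same change on two cores in this assay, a 1.0-fold lower number (0.02 log units; within the scatter) from compound 1 to compound 2 and a 2.5-fold lower number (0.40 log units; beyond the scatter) from compound 3 to compound 4, 2.4-fold (0.38 log units) apart, within the scatter of two such steps. Within the data shown here, that does not show that the change carries over between cores with a fixed size, as there is only one pair on each core, and the added methyl sits two bonds along the chain in one pair and nine bonds along it in the other, so core and place vary together.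

The compounds shown leave open whether a longer chain on the core of compound 4 would move the number further, and what an amine or a carboxylic acid in place of the hydroxyl would give. They also leave open how the short chains of compound 1 and compound 2 would read on the core of compound 3, a comparison that would separate core from chain.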